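Chloro in place of methoxy, tested twice in cytotoxicity

A few compounds are considered here, and "the series" means these few. Any claim that something is new, unique, unknown or untested is made for them only; others in the source may bear on it.

Measured compounds:
compound 1, `COc1ccccc1N1CCN(CC(=O)N2CCN(c3nnc(-c4ccccc4)c(-c4ccccc4)n3)CC2)CC1`, gives 444000 nM
compound 2, `O=C(CN1CCN(c2ccccc2Cl)CC1)N1CCN(c2nnc(-c3ccccc3)c(-c3ccccc3)n2)CC1`, gives 350000 nM
compound 3, `COc1cccc(N2CCN(CC(=O)N3CCN(c4nnc(-c5ccc(Cl)cc5)c(-c5ccc(Cl)cc5)n4)CC3)CC2)c1`, gives 202000 nM

These three numbers all come from an ADME assay on NIH3T3 cells (Mus musculus) for cytotoxicity, read by MTT assay, with a stated time of 24 h; on this read-out lower numbers stand for stronger inhibition and higher numbers for weaker inhibition. Compound 2 differs from compound 1 by chloro in place of methoxy on an aromatic carbon, and this change gave a 1.3-fold lower number from compound 1 to compound 2 (0.10 log units; within the scatter). Compound 3 lies beyond the scatter only from compound 1; its gap to compound 2 is within the scatter. Compound 4, `O=C(CN1CCN(c2cccc(Cl)c2)CC1)N1CCN(c2nnc(-c3ccc(Cl)cc3)c(-c3ccc(Cl)cc3)n2)CC1`, is not yet measured; it differs from compound 3 by chloro in place of methoxy on an aromatic carbon. The difference between the cores of compound 1 and compound 3 is not broken down here. The place of the change is not the same in both pairs: in the first pair the group sits ortho to a large group, in the second pair meta to a large group, so this is the same kind of change, not the same change. Because a 1.3-fold lower number from compound 1 to compound 2 (0.10 log units; within the scatter) was small, compound 4 is expected to give about 170000 nM in this assay, between 80000 nM and 400000 nM. The expected step is a 1.2-fold lower number from compound 3 to compound 4 (0.07 log units; within the scatter).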

Compound 4, half-maximal inhibitory concentration: > 803000 nM
Compound 4 was reported as a limit (the forecaster's own chance of this, stated with the estimate: 10%); middle value at least 4.7-fold (0.67 log units) from the limit.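

Swapping methoxy for chloro gave an at least 3.9-fold higher number from compound 3 to compound 4 (0.59 log units; beyond the scatter), so in this assay the effect seen on one core did not carry over to the other: the same change on two cores in this assay, a 1.3-fold lower number (0.10 log units; within the scatter) from compound 1 to compound 2 and an at least 3.9-fold higher number (0.59 log units; beyond the scatter) from compound 3 to compound 4, at least 5.0-fold (0.70 log units) apart, beyond the scatter of two such steps

Compound 4 gives > 803000 nM, which is a limit of the assay and not a number, so the step from the other compound in its pair has a known lower bound but no known full size: the limit of > 803000 nM in this assay, at which 1 of the 4 values shown sits.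

These two pairs cannot tell whether the core or the place of the group on the ring accounts for the gap, and they give no rule for any further core.

Still open, going by these compounds, is whether the same swap, made at the same place on the ring on both cores, would give matching steps. Also open, on these data alone, is how a different group in that place, such as a methyl, an amine or a carboxylic acid, would behave on each core.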